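Working notes: an unsaturated ring in place of a saturated one

The compounds below may be only part of what the source reports. "The series", "measured", "known", "first", "only" and "open" are said of these compounds alone.

Measured so far in an assay on HEK293 cells for inhibition of Voltage-dependent N-type calcium channel subunit alpha-1B (Homo sapiens), read by patch clamp, using a membrane potential dye; on this read-out lower numbers stand for stronger inhibition and higher numbers for weaker inhibition:
- compound 1 `COc1ccccc1-n1nc(C2CC(C)(C)OC(C)(C)C2)cc1-c1ccc(Cl)cc1` gives 16 nM
- compound 2 `COc1ccccc1-n1nc(C2CC(C)(C)OC(C)(C)C2)cc1-c1csc(Cl)c1` gives 28 nM
- compound 3 `CC1(C)CC(c2cc(-c3ccc(Cl)cc3)n(-c3ccccn3)n2)CC(C)(C)O1` gives 1000 nM

Compound 1 has the lowest number of the three; compound 2 lies within the scatter of it, compound 3 far beyond it. The two measured steps are a 1.8-fold higher number from compound 1 to compound 2 (0.24 log units; within the scatter) and a 63-fold higher number from compound 1 to compound 3 (1.80 log units; beyond the scatter); both change the aromatic substituents on the shared core, not the saturated ring.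

Compound 4 `COc1ccccc1-n1nc(C2=CC(C)(C)OC(C)(C)C2)cc1-c1ccc(Cl)cc1` differs from compound 1 as follows: a group of 10 heavy atoms (9 carbon, 1 oxygen; one six-membered non-aromatic ring with 1 hetero atom) in place of a group of 10 heavy atoms (9 carbon, 1 oxygen; one six-membered non-aromatic ring with 1 hetero atom), on an aromatic carbon. Going by the values given here, no measured step touches this part of the molecule, so nothing in this assay speaks for or against a shift. The expectation is therefore a step of a 1.3-fold higher number from compound 1 to compound 4 (0.10 log units; within the scatter), within the scatter. Compound 4 is estimated at 20 nM, with a range from 7 nM to 60 nM.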

Compound 4, half-maximal inhibitory concentration: 26000 nM
For compound 4 the middle estimate is 1300-fold (3.11 log units) below the measured one; the measured number lies above the stated range.
By their numbers in this assay, from the lowest: compounds 1 and 2 (each within the scatter of the next); then compound 3; then compound 4.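

In this assay, the position on the aromatic carbon of the five-membered ring proves highly sensitive: one double bond outside aromatic rings, with the heavy-atom count unchanged, gives a 1600-fold higher number from compound 1 to compound 4 (3.21 log units; beyond the scatter). This is the largest measured step from compound 1, and the first to touch the saturated ring. Nothing available accounts for the loss.

Going by these compounds, it remains open how other groups behave at this position, such as an unmethylated oxan-4-yl or a piperidin-4-yl group. On these data alone, it is also open whether the double bond has a comparable effect in compound 2.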